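The source may hold more compounds than are shown below. What is called first, only, known or untested is meant among the compounds shown, and "the series" means these compounds.

Measured compounds and their values in a functional assay on PANC-1 cells (Homo sapiens) for inhibition, read by MTT assay, with a stated time of 24 h, tested at 10 uM; on this read-out lower numbers stand for less inhibition and higher numbers for more inhibition at the one concentration tested (going by the name of the read-out):

Compound 1, `CC(C)=CCC1Cc2c(O)cc(=O)n(CCCO)c2CC1(C)C`: compound 1 gives 0%.
Compound 2, `CC(C)=CCC/C(C)=C/CC1Cc2c(O)cc(=O)n(CCCO)c2CC1(C)C`: compound 2 gives 0%.
Compound 3, `CC(C)=CCC/C(C)=C/CC1Cc2c(OCC=C(C)C)cc(=O)n(CCCO)c2CC1(C)C`: compound 3 gives 15.9%.

The first step, (3-methylbut-2-en-1-yl in place of hydrogen on a saturated chain carbon bound to a double-bonded chain carbon), gives no change at the digits printed from compound 1 to compound 2 (within the scatter). The second step, from compound 2 to compound 3, gives a number 15.9 percentage points higher from compound 2 to compound 3 (beyond the scatter), and it leaves compound 3 with the highest number of the three in this assay, beyond the scatter from both compound 1 and compound 2.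

Compound 4, `CC(C)=CCC/C(C)=C/COc1cc(=O)n(CCCO)c2c1CC(C/C=C(\C)CCC=C(C)C)C(C)(C)C2`, is not yet measured. It differs from compound 3 by 3-methylbut-2-en-1-yl in place of hydrogen on a saturated chain carbon bound to a double-bonded chain carbon. This is the same change that turned compound 1 into compound 2, made at a place described in the same words. The difference between the core of compound 1 and the core of compound 3 is not broken down here.

For compound 4 the expected step in this assay is a number 2.1 percentage points higher from compound 3 to compound 4 (within the scatter), because the same change gave no change at the digits printed from compound 1 to compound 2 (within the scatter), so the number is expected to stay close to that of compound 3. Compound 4 is therefore estimated at 18%, with a range from 4% to 34%.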

Compound 4, a percentage reported as inhibition, at one concentration (the size of the read-out at that concentration, not a potency): 3.1%
Beside the measured number, compound 4's estimate is 14.9 percentage points above it; the measured number lies below the stated range.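

In this assay, 3-methylbut-2-en-1-yl in place of hydrogen on a saturated chain carbon bound to a double-bonded chain carbon gives a number 12.8 percentage points lower from compound 3 to compound 4 (beyond the scatter), while 3,7-dimethylocta-2,6-dien-1-yl in place of hydrogen on an oxygen on an aromatic ring gives a number 3.1 percentage points higher from compound 2 to compound 4 (within the scatter). Read alone, the first of these steps differs in kind from the earlier one on the core of compound 1, but the two steps cannot be told apart: the same change on two cores in this assay, no change at the digits printed (within the scatter) from compound 1 to compound 2 and a number 12.8 percentage points lower (beyond the scatter) from compound 3 to compound 4, 12.8 percentage points apart, within the scatter of two such steps. The series therefore does not show that the core alters what this change does, nor does it show that the change carries over unaltered, and a single pair of steps gives no rule for any other core.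

The compounds shown carry only hydrogen, 3-methylbut-2-en-1-yl or 3,7-dimethylocta-2,6-dien-1-yl at these two places. On these data alone, what an amine or a carboxylic acid would give at either place remains open.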